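The source may hold more compounds than are shown below. What is called first, only, known or untested is meant among the compounds shown, and "the series" means these compounds.

Three compounds from one series have been run through an ADME assay for permeability, using PAMPA, at pH 7.4; a lower number here means that the compound crosses the layer more slowly, a higher number that the compound crosses the layer faster. Compound 1, `CC(=O)c1ccc(NC(=O)Nc2cc(C)nc3ccccc23)cc1`, gives 473 10^-6 cm/s in this assay, the highest of the three numbers. Compound 2, `Cc1cc(NC(=O)Nc2cccc([N+](=O)[O-])c2)c2ccccc2n1`, gives 42 10^-6 cm/s in this assay, a step below compound 1 that lies beyond the scatter. Compound 3, `Cc1cc(NC(=O)Nc2ccc3[nH]cnc3c2)c2ccccc2n1`, gives 2 10^-6 cm/s in this assay, the lowest of the three and again well beyond the scatter from compound 1.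

The next compound, compound 4, `Cc1cc(NC(=O)Nc2ccc(C(F)(F)F)cc2)c2ccccc2n1`, has not yet been measured. It differs from compound 1 in one place: trifluoromethyl in place of acetyl on an aromatic carbon. The change sits on an aromatic carbon of a six-membered aromatic ring of carbon only, para to a large group; acetyl leaves and trifluoromethyl enters, so one hydrogen-bond acceptor is gone.

Within the data shown here, no measured pair in this set shows a comparable change, so the expectation rests on compound 1 alone. Compound 4 is expected to give about 450 10^-6 cm/s in this assay, within a range of 200 10^-6 cm/s to 900 10^-6 cm/s. The step from compound 1 that this estimate means, a 1.1-fold lower number from compound 1 to compound 4 (0.02 log units; within the scatter), is expected to stay within the scatter, with no change in direction that can be read as real.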

Compound 4, apparent permeability: 2 10^-6 cm/s
Estimate against measurement, compound 4: 230-fold (2.35 log units) above; measured number outside the range, below it.
By their numbers in this assay, from the lowest: compounds 3 and 4 (each within the scatter of the next); then compound 2; then compound 1.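

In this assay, among these compounds, trifluoromethyl in place of acetyl on this aromatic carbon, para to a large group, gives the first step that can be tied to a single place: a 240-fold lower number from compound 1 to compound 4 (2.37 log units; beyond the scatter). With the rest of compound 1 unchanged, this one exchange takes the number far beyond the scatter, so the group at this position can decide the read-out on its own, at least for this pair. Among the compounds shown here, nothing at hand accounts for the size of this step, and the single pair offers no explanation of it.

As far as these compounds go, whether the step follows from acetyl leaving or from trifluoromethyl entering remains open. From the compounds shown here alone, how a nitrile, a methoxy group, an amide or a plain hydrogen on this same carbon would read in this assay also remains open.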